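A few compounds are considered here, and "the series" means these few. Any claim that something is new, unique, unknown or untested is made for them only; others in the source may bear on it.

In a functional assay on MCF7 cells (Homo sapiens) for antiproliferative activity (on this read-out higher numbers stand for weaker inhibition and lower numbers for stronger inhibition), compound 1 `CC(C)=CCc1cc(C(=O)Nc2cc3ccc(OCCCN4CCCCC4)c(C)c3oc2=O)ccc1O` gives only a limit, > 50000 nM, and no exact number. Among the compounds with values here, compound 2 `CC(C)=CCc1cc(C(=O)Nc2cc3ccc(OCCCNC(C)C)c(C)c3oc2=O)ccc1O` gives 740 nM, so far the only exact number. Compound 3 `COC(=O)CNCCCOc1ccc2cc(NC(=O)c3ccc(O)c(CC=C(C)C)c3)c(=O)oc2c1C` matches compound 2 except on the amine nitrogen, where (methoxycarbonyl)methyl takes the place of isopropyl: (methoxycarbonyl)methyl in place of isopropyl on an amine nitrogen. Within the data shown here, one measured step bears on this change. Putting isopropylamino in place of piperidin-1-yl gave an at least 67-fold lower number from compound 1 to compound 2 (1.82 log units; beyond the scatter), which shows that a change at this amine can have a large effect. That step involves a different pair of groups, however, and does not settle the direction here. A moderate move towards weaker inhibition is expected, with wide uncertainty, and the expected change is a 3.4-fold higher number from compound 2 to compound 3 (0.53 log units; beyond the scatter). The value for compound 3 is estimated at 2500 nM, with a range of 500 nM to 15000 nM.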

Compound 3, half-maximal inhibitory concentration: 2820 nM
For compound 3 the middle estimate is 1.1-fold (0.05 log units) below the measured one, within the range that was stated.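

In this assay, (methoxycarbonyl)methyl in place of isopropyl on the amine nitrogen gives a 3.8-fold higher number from compound 2 to compound 3 (0.58 log units; beyond the scatter). This is a modest step beyond the scatter, so the amine nitrogen can carry this larger group, with its two hydrogen-bond acceptors, at only a limited cost in activity. Swapping piperidin-1-yl for ((methoxycarbonyl)methyl)amino gives an at least 17-fold lower number from compound 1 to compound 3 (1.24 log units; beyond the scatter), so a second open-chain amino group also stands well clear of the piperidin-1-yl compound, whose true size of gap stays unknown, as compound 1 gives a limit and not an exact number: the limit of > 50000 nM in this assay, at which 1 of the 3 values shown sits.

The compounds shown leave open whether a carboxylic acid in place of the methyl ester would hold or lose activity. They also leave open whether a ring amine other than piperidin-1-yl, such as morpholin-4-yl or pyrrolidin-1-yl, would fall as far as compound 1.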